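Dropping Difluoromethoxy from Compound 2: Expected Effect on Potency

The source may report more compounds than this note shows. Statements on the series, on what has been measured and on what is new or still open speak of the compounds shown alone.

Of the compounds shown here, two have so far been tested in a functional assay on MCF7 cells (Homo sapiens) for cytotoxicity, read by MTT assay, with a stated time of 48 h; a lower number here means a stronger inhibitor, a higher number a weaker inhibitor. Compound 1, `O=S(=O)(CCC(F)(Cl)C(F)(F)Cl)c1nc2ccccc2s1`, gives 10100 nM in this assay. Compound 2, `FC(F)=C(F)CCSc1nc2ccc(OC(F)F)cc2[nH]1`, returns only an assay limit in this assay, > 120000 nM, so no exact number is known for it. Compound 2 therefore stands at the limit of > 120000 nM in this assay, at which 1 of the 2 values shown sits, the weaker end of what has been measured so far.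

Compound 3, `FC(F)=C(F)CCSc1nc2ccccc2[nH]1`, has not yet been measured. It differs from compound 2 in a single place: hydrogen in place of difluoromethoxy on an aromatic carbon. Everything else in the two structures is the same. For the measured compounds named here, no pair of measured compounds differs in only one place, so there is no measured step to lean on here, and the starting point itself is a limit rather than a number. The expected change in this assay is a number no higher from compound 2 to compound 3 (the limit leaves the size open), that is, nothing beyond the usual scatter, in either direction. Compound 3 is estimated to give about 120000 nM in this assay, between 40000 nM and 400000 nM, with a real chance that this assay again reports only a limit.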

Compound 3, half-maximal inhibitory concentration: > 120000 nM
Compound 3 was reported as a limit; the forecaster's own chance of this, stated with the estimate: 65%; the middle value lies on the limit itself.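

Compound 3, like compound 2, is reported in this assay only as a limit and not as a number: the limit of > 120000 nM in this assay, at which 2 of the 3 values shown sit. For the compounds shown here, no step can therefore be read between compound 2 and compound 3. The compounds shown leave open whether hydrogen in place of difluoromethoxy changes potency at all, and how potent either compound really is.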